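Naphthyl in place of tert-butylphenyl on the sulfur

A few compounds are considered here, and "the series" means these few. Any claim that something is new, unique, unknown or untested is made for them only; others in the source may bear on it.

Compound 1 `Nc1ccccc1NC(=O)/C=C/c1ccc(CSc2ccc(F)cc2)cc1`: 1190 nM
Compound 2 `Nc1ccccc1NC(=O)c1ccc(CSc2cccc(F)c2)cc1`: "not determined" (no result reported)
Compound 3 `CC(C)(C)c1ccc(SCc2ccc(/C=C/C(=O)Nc3ccccc3N)cc2)cc1`: 640 nM

In a functional assay on A549 cells (Homo sapiens) for antiproliferative activity, read by CCK-8 assay, with a stated time of 72 h (on this read-out lower numbers stand for stronger inhibition and higher numbers for weaker inhibition), compound 3 and compound 1 differ only within the scatter, a 1.9-fold lower number from compound 1 to compound 3 (0.27 log units; within the scatter), so neither stands apart from the other; compound 2 has no reported number in this assay. Compound 4 `Nc1ccccc1NC(=O)/C=C/c1ccc(CSc2cccc3ccccc23)cc1` differs from compound 3 in one place: naphthalen-1-yl in place of 4-(tert-butyl)phenyl on a sulfur. Within the data shown here, the only measured step, tert-butyl in place of fluoro on an aromatic carbon, stayed within the scatter, and no measured step exchanges the whole ring attached to the sulfur. With nothing indicating a shift, no change beyond the scatter is expected, a 1.1-fold higher number from compound 3 to compound 4 (0.04 log units; within the scatter). Compound 4 is therefore estimated at 700 nM, between 300 nM and 1600 nM.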

Compound 4, half-maximal inhibitory concentration: 830 nM
For compound 4 the middle estimate is 1.2-fold (0.07 log units) below the measured one; low and high end bracket the measured number.
By their numbers in this assay, from the lowest: compounds 3, 4 and 1 (each within the scatter of the next).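

Exchanging the whole ring on the sulfur can now be read in this assay: naphthalen-1-yl in place of 4-(tert-butyl)phenyl gives a 1.3-fold higher number from compound 3 to compound 4 (0.11 log units; within the scatter), and in place of 4-fluorophenyl gives a 1.4-fold lower number from compound 1 to compound 4 (0.16 log units; within the scatter). Among these three compounds, then, having one or two aromatic rings on the sulfur makes no difference beyond the scatter. Nothing available explains this result.

As far as these compounds go, whether a ring carrying an amine or a carboxylic acid, or a plain alkyl chain, on the sulfur would also stay within the scatter remains open.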